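This account rests on a few compounds, and the source may have more. Where it says the series, first, only, none or still open, it means among the compounds named here.

- Compound 1 `CCOC(=O)c1ccc2ccc(Oc3ccnc(C(=O)NC)c3)cc2c1`: 20800 nM
- Compound 2 `CCC(C)OC(=O)c1ccc2ccc(Oc3ccnc(C(=O)NC)c3)cc2c1`: 16000 nM

In an ADME assay on H1-HeLa cells (Homo sapiens) for cytotoxicity, read by MTT assay, with a stated time of 3 days (on this read-out lower numbers stand for higher toxicity in this test and higher numbers for lower toxicity in this test), compound 2 gives 16000 nM, within the scatter of compound 1 at 20800 nM. Compound 3 `CNC(=O)c1cc(Oc2ccc3ccc(C(=O)Oc4ccccc4)cc3c2)ccn1` is still unmeasured. Its change is phenyl in place of sec-butyl on an oxygen next to a carbonyl group. For the measured compounds named here, only one measured step bears on this, a 1.3-fold lower number from compound 1 to compound 2 (0.11 log units; within the scatter), and it also concerns the chain on that oxygen. Going by the values given here, no measured compound carries a ring there, so this guide is weak. The expected step is a 1.1-fold lower number from compound 2 to compound 3 (0.06 log units; within the scatter), with no shift beyond the scatter. Compound 3 is estimated at 14000 nM, with an expected range of 5000 nM to 35000 nM.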

Compound 3, half-maximal cytotoxic concentration: > 100000 nM
Compound 3 ended at the assay's limit; the forecaster's own chance of this, stated with the estimate: 10%; middle value at least 7.1-fold (0.85 log units) from the limit.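

In this assay, the group on this oxygen can shift the read-out beyond the scatter: phenyl in place of sec-butyl gives an at least 6.2-fold higher number from compound 2 to compound 3 (0.79 log units; beyond the scatter), and phenyl in place of ethyl gives an at least 4.8-fold higher number from compound 1 to compound 3 (0.68 log units; beyond the scatter). The earlier swap between two open chains showed no such shift, so the change to a ring points toward lower toxicity in this test. Compound 3 stands at a limit of the assay, not at a number: the limit of > 100000 nM in this assay, at which 1 of the 3 values shown sits.

The compounds shown leave open how far above that limit compound 3 lies. They also leave open whether any ring would do the same, and a cyclohexyl group on that oxygen would address this.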